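The compounds below may be only part of what the source reports. "The series", "measured", "known", "first", "only" and "open" are said of these compounds alone.

Measured in a functional assay; on this read-out higher numbers stand for weaker inhibition and lower numbers for stronger inhibition:
- compound 1 `CC(C)=CCOc1ccc2c(c1)OC(c1ccccc1)CC2=O`: 6070 nM
- compound 2 `COc1ccc(C2CC(=O)c3ccc(OCC=C(C)C)cc3O2)cc1`: 10200 nM
- compound 3 `CC(C)=CCOc1ccc2c(c1)OC(c1ccc(O)cc1)CC2=O`: 6670 nM

For the measured compounds named here, compound 1 gives 6070 nM, and all three values lie within the scatter of one another, so no compound in this small set stands apart.

Compound 4 `CC(C)=CCOc1cc(O)c2c(c1)OC(c1ccccc1)CC2=O` differs from compound 1 by a single change, (hydroxy in place of hydrogen on an aromatic carbon). It is hydroxy in place of hydrogen on an aromatic carbon of a six-membered aromatic ring of carbon only, part of a fused or bridged system of two rings, ortho to a fused ring and meta to a (3-methylbut-2-en-1-yl)oxy group.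

The closest measured precedent is the same kind of swap at a different aromatic carbon, a 1.1-fold higher number from compound 1 to compound 3 (0.04 log units; within the scatter). Methoxy at that other carbon gave a 1.7-fold higher number from compound 1 to compound 2 (0.23 log units; within the scatter), and taking off its methyl gave a 1.5-fold lower number from compound 2 to compound 3 (0.18 log units; within the scatter). None of these steps goes beyond the scatter. Going by the values given here, no measured compound carries a group at the new place, however, so they are only a loose guide, and the range must stay wide.

In this assay, no shift beyond the scatter is expected, and the estimated step is a 1.1-fold lower number from compound 1 to compound 4 (0.04 log units; within the scatter). The estimate for compound 4 is 5500 nM, with an expected range of 2200 nM to 13000 nM.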

Compound 4, half-maximal inhibitory concentration: 7320 nM
The estimate for compound 4 lay 1.3-fold (0.12 log units) below the measured number, and the stated range covers the measured number.
By their numbers in this assay, from the lowest: compounds 1, 3, 4 and 2 (each within the scatter of the next).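

In this assay, adding a hydroxy group on the aromatic carbon ortho to a fused ring and meta to the (3-methylbut-2-en-1-yl)oxy group gives a 1.2-fold higher number from compound 1 to compound 4 (0.08 log units; within the scatter), so this position now has a measured result, and this change leaves the read-out within the scatter. The earlier compounds shown here showed this only for the same swap at a different aromatic carbon, a 1.1-fold higher number from compound 1 to compound 3 (0.04 log units; within the scatter), so across these two places, adding a hydroxy group produces no step that can be told from repeat-to-repeat variation. No independent measurement is available to explain this result.

The compounds shown leave open whether an amine or a carboxylic acid on this same aromatic carbon would also stay within the scatter or would produce a clear step in either direction. Because the (3-methylbut-2-en-1-yl)oxy group is present in all four compounds, they also leave open whether a hydroxy group at this position would behave in the same way if that group were replaced by a shorter chain, such as an ethoxy group.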